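The source may hold more compounds than are shown below. What is called first, only, known or untested is meant among the compounds shown, and "the series" means these compounds.

Compound 1 `O=c1[nH]cc(S(=O)(=O)Nc2ccccc2-c2cn(-c3ccccc3)nn2)c(=O)[nH]1` gives the highest of the two numbers at hand: in a functional assay on A549 cells (Homo sapiens) for antiproliferative activity, read by MTT assay, with a stated time of 24 h (on this read-out lower numbers stand for stronger inhibition and higher numbers for weaker inhibition), compound 1 gives 6790 nM. Among the measured compounds shown here, compound 2 `Cc1ccccc1-n1cc(-c2ccccc2NS(=O)(=O)c2c[nH]c(=O)[nH]c2=O)nn1` gives 3210 nM, and the single measured step, a 2.1-fold lower number from compound 1 to compound 2 (0.33 log units; beyond the scatter), placed a methyl on the phenyl that sits on the triazole. Compound 3 `Cc1cccc(-n2cc(-c3ccccc3NS(=O)(=O)c3c[nH]c(=O)[nH]c3=O)nn2)c1` carries the same kind of change at a different spot: methyl in place of hydrogen on an aromatic carbon. For the measured compounds named here, since the only step that bears on it was modest, a step of similar size or smaller, toward a lower number, is expected, namely a 1.6-fold lower number from compound 1 to compound 3 (0.21 log units; within the scatter). Compound 3 is therefore estimated at 4200 nM, with a range from 2000 nM to 9000 nM.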

Compound 3, half-maximal inhibitory concentration: 1870 nM
Estimate against measurement, compound 3: 2.2-fold (0.35 log units) above, and the stated range ends above it.
By their numbers in this assay, from the lowest: compounds 3 and 2 (each within the scatter of the next); then compound 1.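

In this assay a methyl at this second spot on the phenyl gives a 3.6-fold lower number from compound 1 to compound 3 (0.56 log units; beyond the scatter) and so shows that the lower number is not tied to a single spot on that ring. Putting 3-methylphenyl in place of 2-methylphenyl gives a 1.7-fold lower number from compound 2 to compound 3 (0.23 log units; within the scatter) and so does not separate the two spots. Nothing at hand explains these numbers. Still open, as far as these compounds go, is how this position reads with a chlorine atom, a methoxy group or an amine in place of the methyl. From the compounds shown here alone, a longer chain such as ethyl is equally open.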